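A few compounds are considered here, and "the series" means these few. Any claim that something is new, unique, unknown or untested is made for them only; others in the source may bear on it.

Measured so far:
compound 1 `Cc1cccc(COc2ccc3c(c2)[C@@H](O)CN(C)C3)c1` — in an ADME assay on Vero cells (Chlorocebus sabaeus) for cytotoxicity, read by sulforhodamine B assay, with a stated time of 72 h (a lower number here means a stronger inhibitor, a higher number a weaker inhibitor), compound 1 gives > 50000 nM, a limit of this assay rather than a number.
compound 2 `CN1Cc2ccc(OCC3CCCCC3)cc2[C@@H](O)C1` — in this assay compound 2 gives 65600 nM.

Within the data shown here, compound 2 holds the only number in this assay; the other value is a limit. The step that the limit leaves unreadable from compound 1 to compound 2 cannot be sized because of the limit of > 50000 nM in this assay, at which 1 of the 2 values shown sits. Compound 3 `CN1Cc2ccc(OCc3cccnc3)cc2[C@@H](O)C1` differs from compound 2 by pyridin-3-yl in place of cyclohexyl on a saturated chain carbon bound to an oxygen on an aromatic ring. No measured step reproduces this change, and the one step shown is unreadable, so the expectation rests on compound 2 alone: for compound 3 the expected step is a 1.1-fold higher number from compound 2 to compound 3 (0.03 log units; within the scatter), none beyond the scatter. Compound 3 is estimated at 70000 nM, within 30000 nM to 160000 nM.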

Compound 3, half-maximal inhibitory concentration: > 50000 nM
Compound 3 gave a limit, no number; the forecaster's own chance of this, stated with the estimate: 50%; the middle value lies beyond the limit too.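

Compound 3 gives a limit rather than a number in this assay, as compound 1 does, so no step from compound 1 or compound 2 to compound 3 can be read: the limit of > 50000 nM in this assay, at which 2 of the 3 values shown sit.

Going by these compounds, how pyridin-3-yl compares with cyclohexyl or 3-methylphenyl in this assay stays open.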